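Fluoro for methoxy at the limit of the assay

The source may report more compounds than this note shows. Statements on the series, on what has been measured and on what is new or still open speak of the compounds shown alone.

In a functional assay on MCF7 cells (Homo sapiens) for antiproliferative activity, read by luminescence and CellTiter-Glo, with a stated time of 48 h (on this read-out lower numbers stand for stronger inhibition and higher numbers for weaker inhibition), compound 1 (`COc1ccc(/C=C/[C@H]2CC=CC(=O)O2)cc1`) gives > 100000 nM, which is a limit and not a number. Compound 1 therefore stands at the limit of > 100000 nM in this assay, at which 2 of the 3 values shown sit. Compound 3 (`O=C1C=CC[C@H](/C=C/C2CCCCC2)O1`) gives > 100000 nM, also a limit. For the measured compounds named here, compound 2 (`COc1ccc(/C=C/[C@@H]2CC=CC(=O)O2)cc1`) gives 88700 nM, the only actual number so far. Going by the values given here, the one measured step, an at least 1.1-fold lower number from compound 1 to compound 2 (0.05 log units; that floor lies within the scatter), lies within the scatter and concerns only (the fact that compounds 1 and 2 differ only in the configuration as drawn). Compound 4 (`O=C1C=CC[C@H](/C=C/c2ccc(F)cc2)O1`) keeps the core of compound 1 and changes one group: fluoro in place of methoxy on an aromatic carbon. Among the compounds with values here, no measured step tests this exchange, so only a small change is expected. The estimated step is an at least 1.2-fold lower number from compound 1 to compound 4 (0.09 log units; that floor lies within the scatter). Compound 4 is expected at an estimated 80000 nM, within a range from 30000 nM to 200000 nM.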

Compound 4, half-maximal inhibitory concentration: 76200 nM
Estimate against measurement, compound 4: 1.0-fold (0.02 log units) above; the measured number falls inside the stated range.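

Fluoro in place of methoxy on an aromatic carbon gives the first reading of this position: the step is an at least 1.3-fold lower number from compound 1 to compound 4 (0.11 log units; that floor lies within the scatter) and it is no more than a floor. In this assay compound 1 gives > 100000 nM as a limit and not a number. The full size of this exchange therefore stays unread, and compound 4 shows only that fluoro at this position gives an actual number in this assay.

On these data alone, whether an amine or a carboxylic acid on the same aromatic carbon would move the number beyond the scatter stays open. So does the effect of reversing the stereocentre at the saturated ring carbon of compound 4.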